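Acyl swap on the shared amide: solubility notes

A few compounds are considered here, and "the series" means these few. Any claim that something is new, unique, unknown or untested is made for them only; others in the source may bear on it.

Compound 1 `Cc1cc(C(=O)Nc2cc(Oc3ccc4nc(NC(=O)C5CC5)nn4c3)ccc2C)n(C)n1` holds the higher of the two numbers recorded in a physicochemical assay for solubility, measured as kinetic solubility, at pH 6.8 (on this read-out higher numbers stand for higher solubility and lower numbers for lower solubility), where compound 1 gives 53 ug/mL. Among the measured compounds shown here, the only other measured member, compound 2 `Cc1cc(C(=O)Nc2cccc(Oc3ccc4nc(NC(=O)C5CC5)cn4c3)c2)n(C)n1`, gives 0.73 ug/mL in this assay. For the measured compounds named here, compound 2 differs from compound 1 in more than one place, so the two values show only that the gap between them lies beyond the scatter; no single-change step between measured compounds is available.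

Compound 3 `Cc1ccc(Oc2ccc3nc(NC(=O)C4CC4)nn3c2)cc1NC(=O)CC(C)C` is the next candidate. Against compound 1 the change is isobutyl in place of 1,3-dimethyl-1H-pyrazol-5-yl on a carbonyl carbon; cut one bond further out, the same difference reads (1,3-dimethyl-1H-pyrazol-5-yl)carbonyl to isobutylcarbonyl, that is ((1,3-dimethyl-1H-pyrazol-5-yl)carbonyl)amino to (isobutylcarbonyl)amino. The group that leaves is a five-membered aromatic ring with hydrogen-bond acceptors; the group that enters has no ring and no acceptors. Going by the values given here, with no measured step to anchor it, the expectation in this assay is a downward step of a 4.4-fold lower number from compound 1 to compound 3 (0.65 log units; beyond the scatter), beyond the scatter. Compound 3 is accordingly estimated at 12 ug/mL, with a range from 2.5 ug/mL to 45 ug/mL. Among the compounds with values here, this rests on compound 1 alone, because compound 1 gives 53 ug/mL and nothing else in the set shares the single change.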

Compound 3, solubility: 12 ug/mL
Compound 3: middle estimate and measured number agree at the digits printed; the measured number falls inside the stated range.
By their numbers in this assay, from the lowest: compound 2; then compound 3; then compound 1.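

Replacing the ring on this carbonyl carbon gives the series its first single-change reading: in this assay, isobutyl in place of 1,3-dimethyl-1H-pyrazol-5-yl on a carbonyl carbon gives a 4.4-fold lower number from compound 1 to compound 3 (0.65 log units; beyond the scatter) and so shows that the read-out responds to the group at this position. The direction holds for this one pair only, and the exchange alters several counted features at once: the group that leaves has a five-membered aromatic ring and 2 hydrogen-bond acceptors, while isobutyl has no ring and 0 hydrogen-bond acceptors, so the step belongs to the whole exchange and not to any one of these features. No measurement at hand bears on the reason for the lower number.

On these data alone, whether an oxazole, a phenyl ring or a pyridine on the same carbonyl carbon would stay nearer compound 1 or nearer compound 3 remains open, as does the outcome for an open chain ending in a tertiary amine or a carboxylic acid. Also open, as far as these compounds go, is whether the same exchange would give a step of similar size and direction on the core of compound 2.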